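A solubility estimate for an aryl-for-aryloxy swap

The source may report more compounds than this note shows. Statements on the series, on what has been measured and on what is new or still open speak of the compounds shown alone.

Compound 1 `c1ccc(Oc2ccc3c(NCCCNCc4ccco4)ccnc3c2)cc1` is the starting point. In a physicochemical assay for solubility, with a stated time of 18 h, at pH 7.4 (on this read-out lower numbers stand for lower solubility and higher numbers for higher solubility), compound 1 gives 14500 nM. Two related compounds sit alongside it: compound 2 `COc1cccc(Oc2ccc3c(NCCCNCc4cccc(OC)c4O)ccnc3c2)c1`, which in this assay gives 14500 nM, and compound 3 `CC(C)(C)c1ccc(Oc2ccc3c(NCCCNCc4ccco4)ccnc3c2)cc1`, which gives 14500 nM. Compound 1 is therefore level with both at the digits shown, with nothing between the three that goes beyond the usual scatter. Among the measured compounds shown here, the one single-point step among them, tert-butyl in place of hydrogen on an aromatic carbon, shows no change at the digits printed from compound 1 to compound 3 (within the scatter).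

The compound not yet measured is compound 4 `COc1ccc(-c2ccc3c(NCCCNCc4ccco4)ccnc3c2)cc1`. Its change from compound 1 is 4-methoxyphenyl in place of phenoxy on an aromatic carbon. The phenoxy group leaves and a 4-methoxyphenyl group enters at the same aromatic carbon of the shared core, a carbon that is meta to a fused ring and para to a fused ring. For the measured compounds named here, the only step that bears on it, from compound 1 to compound 3, shows no change, and compound 2 with a different set of groups also sits at the same level. On that basis compound 4 is expected to show no change at the digits printed from compound 1 to compound 4 (within the scatter). The estimate for compound 4 is 14500 nM, with an expected range from 6000 nM to 30000 nM.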

Compound 4, solubility: 32000 nM
Compound 4: the middle estimate sits 2.2-fold (0.34 log units) below what was measured, outside the stated range (above it).
By their numbers in this assay, from the lowest: compounds 1, 2 and 3 (each within the scatter of the next); then compound 4.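

In this assay, 4-methoxyphenyl in place of phenoxy gives a 2.2-fold higher number from compound 1 to compound 4 (0.34 log units; beyond the scatter) and is the only step shown that passes the usual scatter, while tert-butyl in place of hydrogen gives no change at the digits printed from compound 1 to compound 3 (within the scatter). So this aromatic carbon of the shared core is a place where a change can move the read-out, though the move is modest and rests on one pair of compounds. Phenoxy and 4-methoxyphenyl match in their aromatic ring type, hydrogen-bond donors, hydrogen-bond acceptors and net charge, so these counts do not separate them, and no other data here bear on the step.

Going by these compounds, it remains open whether the step would persist with an unsubstituted phenyl group on the same carbon, which would separate the role of the methoxy group from that of the lost oxygen link. On these data alone, how a morpholine or a carboxylic acid at this position would read out also remains unknown.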